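The source may report more compounds than this note shows. Statements on the series, on what has been measured and on what is new or still open speak of the compounds shown alone.

The three measured compounds share a core that carries a chain ending in a secondary amine and a benzyl-type group at one end. In a physicochemical assay for acid dissociation, compound 1 `c1ccc(Oc2ccc3c(NCCCNCc4ccco4)ccnc3c2)cc1` gives 9.28, compound 2 `COc1ccc(F)cc1CNCCCNc1ccnc2cc(CCC(C)C)ccc12` gives 9.47, and compound 3 `COc1cccc(CNCCCNc2ccnc3cc(Cc4ccccc4)ccc23)c1O` gives 9.47. Compound 3 is level with compound 2 at the digits shown, the two together the highest of the three, and the value of compound 1 lies lower by an amount within the scatter. Compound 4 `COc1cccc(CNCCCNc2ccnc3cc(CCC(C)C)ccc23)c1O` has not been measured. It differs from compound 3 in one place: isobutyl in place of phenyl on a saturated chain carbon bound to an aromatic carbon. Compound 2 already carries isopentyl at this ring and sits level with compound 3, so the step from compound 3 to compound 4 is expected to be a number 0.02 log units lower from compound 3 to compound 4 (within the scatter), none beyond the scatter. Compound 4 is therefore estimated at 9.45, between 9.15 and 9.75.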

Compound 4, acid dissociation constant: 9.47
The estimate for compound 4 lay 0.02 log units below the measured number, and the stated range covers the measured number.
By their numbers in this assay, from the lowest: compounds 1, 2, 3 and 4 (each within the scatter of the next).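

In this assay, among these compounds, there is no change at the digits printed from compound 3 to compound 4 (within the scatter) with isobutyl in place of phenyl on a saturated chain carbon bound to an aromatic carbon, the first direct comparison at this position. Among the compounds shown here, there is also no change at the digits printed from compound 2 to compound 4 (within the scatter) with 2-hydroxy-3-methoxyphenyl in place of 5-fluoro-2-methoxyphenyl on a saturated chain carbon bound to an amine nitrogen, the first direct comparison at that second position. Nothing at hand explains either step. Phenyl and isobutyl hold carbon only, so how an amine or a carboxylic acid on the same chain carbon would read remains open.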